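Switching dimethylamino for diethylamino on the chain

The compounds below may be only part of what the source reports. "The series", "measured", "known", "first", "only" and "open" are said of these compounds alone.

Compound 3 `CC(C)c1ccc2c(c1)[n+]([O-])c(NCCN(C)C)n[n+]2[O-]` gives 42000000 nM in a physicochemical assay for solubility, in the presence of a further agent that is not named here; on this read-out higher numbers stand for higher solubility and lower numbers for lower solubility. Compound 1 `CCN(CC)CCNc1n[n+]([O-])c2ccc(Cl)cc2[n+]1[O-]` gives 23000000 nM in this assay, a number that sits within the usual scatter of the figure for compound 3. For compound 2 `CCN(CC)CCNc1n[n+]([O-])c2ccc(C)cc2[n+]1[O-]` this assay reports only a limit, > 49000000 nM, not a number. Within the data shown here, the one measured step, an at least 2.1-fold higher number from compound 1 to compound 2 (0.32 log units; beyond the scatter), concerns the group on the aromatic ring and touches the limit described by the limit of > 49000000 nM in this assay, at which 1 of the 3 values shown sits.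

Compound 4 `CCN(CC)CCNc1n[n+]([O-])c2ccc(C(C)C)cc2[n+]1[O-]` keeps the isopropyl group of compound 3 and differs only on the chain: diethylamino in place of dimethylamino on a saturated chain carbon, two bonds along the chain from a nitrogen on an aromatic ring. Among the measured compounds shown here, no measured step changes this part of the molecule, so the only guide is the closeness of the numbers for compound 1 and compound 3, which share the same amine end and give figures within the scatter of each other. For compound 4 in this assay no step beyond the scatter is expected, and its solubility is estimated at 35000000 nM, likely between 15000000 nM and 60000000 nM. The expected step is a 1.2-fold lower number from compound 3 to compound 4 (0.08 log units; within the scatter).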

Compound 4, solubility: 45000000 nM
Compound 4: middle estimate off by 1.3-fold (0.11 log units), on the low side; the range from low to high includes it.
By their numbers in this assay, from the lowest: compounds 1, 3 and 4 (each within the scatter of the next). At a limit, above all of these: compound 2.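

Among these compounds, no earlier pair tested the amine end of the chain, and here diethylamino in place of dimethylamino on this saturated chain carbon gives a 1.1-fold higher number from compound 3 to compound 4 (0.03 log units; within the scatter) in this assay. On the aromatic carbon, isopropyl in place of chloro also stays within the scatter (a 2.0-fold higher number from compound 1 to compound 4 (0.29 log units; within the scatter)), so the readings of these compounds cannot be told apart. Compound 2 is reported only as a limit, not a number: (the limit of > 49000000 nM in this assay, at which 1 of the 4 values shown sits). Isopropyl in place of methyl on the aromatic carbon gives an at least 1.0-fold lower number from compound 2 to compound 4 (0.03 log units; that floor lies within the scatter), and that floor is all this step shows, so its full size cannot be read.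

The compounds shown leave open whether a cyclic amine such as morpholine or piperidine at the chain end would stay as close as diethylamino does. They also leave open how a longer chain between the two nitrogens would read in this assay.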